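Alkynyl variation on a shared core: cyclopropyl replaces pyrimidinyl

This account rests on a few compounds, and the source may have more. Where it says the series, first, only, none or still open, it means among the compounds named here.

Three alkynyl analogues of one core have numbers in an assay on CHO cells for displacement of a labelled ligand from adenosine receptor A1 (Homo sapiens), read by scintillation counting, with a stated time of 60 min, tested at 10 uM; a lower number here means less inhibition, a higher number more inhibition at the concentration tested (going by the name of the read-out). Compound 1 `CNC(=O)[C@@]12C[C@@H]1[C@@H](n1cnc3c(NC)nc(C#Cc4ccccc4F)nc31)[C@H](O)[C@@H]2O` gives 20%, compound 2 `CNC(=O)[C@@]12C[C@@H]1[C@@H](n1cnc3c(NC)nc(C#Cc4ccccc4OC)nc31)[C@H](O)[C@@H]2O` gives 12%, and compound 3 `CNC(=O)[C@@]12C[C@@H]1[C@@H](n1cnc3c(NC)nc(C#Cc4ncccn4)nc31)[C@H](O)[C@@H]2O` gives 25%. Compound 3 holds the highest of the three numbers, separated from compound 2 by a number 13 percentage points higher from compound 2 to compound 3 (beyond the scatter) and from compound 1 by a number 5 percentage points higher from compound 1 to compound 3 (within the scatter); the step of a number 8 percentage points lower from compound 1 to compound 2 (within the scatter) is likewise small. Compound 4 `CNC(=O)[C@@]12C[C@@H]1[C@@H](n1cnc3c(NC)nc(C#CC4CC4)nc31)[C@H](O)[C@@H]2O` differs from compound 3 by cyclopropyl in place of pyrimidin-2-yl on a triple-bonded carbon. Going by the values given here, no measured step swaps a heteroaryl for a saturated ring, so the three aryl-to-aryl steps bear only loosely on it; all stayed modest. A step of a number 8 percentage points lower from compound 3 to compound 4 (within the scatter) in this assay is therefore expected, small and likely downward. Compound 4 is estimated at 17%, within 4% to 30%.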

Compound 4, a percentage reported as inhibition, at one concentration (the size of the read-out at that concentration, not a potency): 38%
Compound 4: the middle estimate sits 21 percentage points below what was measured; the measured number lies above the stated range.
By their numbers in this assay, from the lowest: compounds 2, 1 and 3 (each within the scatter of the next, the first and the last beyond it); then compound 4.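

Cyclopropyl on the triple-bonded carbon stands clear of all three aromatic groups in this assay (a number 13 percentage points higher from compound 3 to compound 4 (beyond the scatter)) (a number 26 percentage points higher from compound 2 to compound 4 (beyond the scatter)) (a number 18 percentage points higher from compound 1 to compound 4 (beyond the scatter)). An aromatic ring at this position is therefore not required for the inhibition seen in this series at the concentration tested. Nothing available accounts for the higher number of compound 4.

Open, from the compounds shown here alone, is whether a larger saturated ring such as cyclohexyl or an open chain such as tert-butyl would give a higher or lower number. Going by these compounds, an aminomethyl group on the same carbon also remains untested within these compounds.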